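Solubility of a spirocyclic amine and its fused bicyclic replacement

The compounds below may be only part of what the source reports. "The series", "measured", "known", "first", "only" and "open" are said of these compounds alone.

Of the compounds shown here, three sharing one core have been measured in a physicochemical assay for solubility, read by spectrophotometry, in phosphate buffer, with a stated time of 2 h, at pH 7.4; a higher number here means a more soluble compound, a lower number a less soluble compound. Compound 1 `COc1ccc2[nH]c(C(=O)N3CC(=O)N(Cc4ccccc4)[C@@H](COCc4ccccc4)C3)cc2c1` gives 8800 nM. Compound 2 `COc1ccc2[nH]c(C(=O)N3CC(=O)N(Cc4ccccc4)[C@@H](CN4CCCC4)C3)cc2c1` reaches only a limit of the assay, > 25000 nM. Compound 3 `COc1ccc2[nH]c(C(=O)N3CC(=O)N(Cc4ccccc4)[C@@H](CN4CC5(CCC5)C4)C3)cc2c1` gives 60700 nM, the highest of the two numbers shown; the nearest number is that of compound 1, and the step of a 6.9-fold higher number from compound 1 to compound 3 (0.84 log units; beyond the scatter) stands beyond the scatter. The step of an at least 2.8-fold higher number from compound 1 to compound 2 (0.45 log units; beyond the scatter) is also beyond the scatter, whereas the step that the limit leaves unreadable from compound 2 to compound 3 cannot be read in size, because compound 2 sits at the limit of > 25000 nM in this assay, at which 1 of the 3 values shown sits.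

Compound 4 `COc1ccc2[nH]c(C(=O)N3CC(=O)N(Cc4ccccc4)[C@@H](CN4CCn5cccc5C4)C3)cc2c1` differs from compound 3 by a group of 9 heavy atoms (7 carbon, 2 nitrogen; one five-membered aromatic ring with 1 hetero atom, one six-membered non-aromatic ring with 2 hetero atoms) in place of a group of 7 heavy atoms (6 carbon, 1 nitrogen; one four-membered non-aromatic ring of carbon only, one four-membered non-aromatic ring with 1 hetero atom), on a saturated chain carbon bound to a saturated ring carbon. Among the compounds with values here, no measured step changes the group in exactly this way; the only steps at the same place, a 6.9-fold higher number from compound 1 to compound 3 (0.84 log units; beyond the scatter) and a step that the limit leaves unreadable from compound 2 to compound 3, exchange amine or ether groups and do not carry an aromatic ring into the new group. The expectation for compound 4 therefore rests loosely on these, and the estimated step of a 2.0-fold lower number from compound 3 to compound 4 (0.31 log units; beyond the scatter) is a modest move downward from compound 3, possibly within the scatter. Compound 4 is estimated to give 30000 nM in this assay, with a range from 12000 nM to 80000 nM.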

Compound 4, solubility: 29700 nM
Compound 4: middle estimate off by 1.0-fold (0.00 log units), on the high side; the range from low to high includes it.
By their numbers in this assay, from the lowest: compound 1; then compound 4; then compound 3.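

In this assay, within the data shown here, the change at this place, on a saturated chain carbon bound to a saturated ring carbon, now brings in a group with a five-membered aromatic ring and a six-membered non-aromatic ring with 2 hetero atoms, and the result is a 2.0-fold lower number from compound 3 to compound 4 (0.31 log units; beyond the scatter); this is the first readable step among the amine groups here, and it shows that the number at this place moves with the choice of amine group. The same group still stands clear of the benzyloxy group, with a 3.4-fold higher number from compound 1 to compound 4 (0.53 log units; beyond the scatter), so an aromatic ring in the group at this place does not by itself bring the number down to that of compound 1. The step between compound 2 and compound 4 cannot be read, because compound 2 stands at a limit and not at a number: the limit of > 25000 nM in this assay, at which 1 of the 4 values shown sits.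

The compounds shown leave open whether the lower number of compound 4 goes with its aromatic ring or with the larger group as a whole. A fully saturated fused bicyclic amine at this place would separate the two, and a morpholine or a carboxylic acid would show how far the number moves with a different kind of group.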